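Triazole series: 2-chlorophenyl in place of 4-cyanophenyl

The source may report more compounds than this note shows. Statements on the series, on what has been measured and on what is new or still open speak of the compounds shown alone.

The series shares one core; compound 1 `C=CCc1ccc(OCc2cn(-c3cccc([N+](=O)[O-])c3)nn2)c(O)c1` and compound 2 `C=CCc1ccc(OCc2cn(-c3ccc(C#N)cc3)nn2)c(O)c1` differ only in the group on the aromatic nitrogen. In a functional assay on HepG2 cells (Homo sapiens) for inhibition, read by MTT assay, with a stated time of 72 h, tested at 50 uM (a higher number here means more inhibition of growth at the concentration tested, a lower number less inhibition of growth), compound 1 gives 30.2% and compound 2 gives 12.1%, the lower of the two numbers, with compound 1 standing beyond the scatter above it. Compound 3 `C=CCc1ccc(OCc2cn(-c3ccccc3Cl)nn2)c(O)c1` is not yet measured; it carries the change (2-chlorophenyl in place of 4-cyanophenyl on an aromatic nitrogen). Going by the values given here, no steps between measured compounds are known, so the size of this step is open; a small rise is expected, not certainly beyond the scatter. In this assay compound 3 is estimated at 20%, between 5% and 40%, a step of a number 7.9 percentage points higher from compound 2 to compound 3 (within the scatter).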

Compound 3, percent growth inhibition at one concentration: 4.7%
Compound 3: middle estimate off by 15.3 percentage points, on the high side, and the stated range ends above it.
By their numbers in this assay, from the lowest: compounds 3 and 2 (each within the scatter of the next); then compound 1.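

In this assay, 2-chlorophenyl in place of 4-cyanophenyl on the aromatic nitrogen gives a number 7.4 percentage points lower from compound 2 to compound 3 (within the scatter), the first step read at this position. This change of both substituent and its place on the aryl ring does not separate compound 2 from compound 3, and neither approaches compound 1 at 30.2%. No measurement at hand accounts for the size of this step.

Because substituent and ring place change together, their separate contributions remain unresolved. Also open, on these data alone, is how an amine or a carboxylic acid on this aryl ring would read.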